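The source may hold more compounds than are shown below. What is called first, only, known or untested is meant among the compounds shown, and "the series" means these compounds.

Compound 3 `O=C(OCC1CCCN(CCCc2ccccc2)C1)c1ccccc1N1C(=O)CC(C2CCCC2)C1=O` stands lowest of the three numbers in a functional assay with Neuronal acetylcholine receptor; alpha3/beta4 (Homo sapiens) as the target; on this read-out higher numbers stand for weaker inhibition and lower numbers for stronger inhibition: compound 3 gives 1200 nM, while compound 2 `CC(C)C1CC(=O)N(c2ccccc2C(=O)OCC2CCCN(CCCc3ccccc3)C2)C1=O` gives 2500 nM and compound 1 `CC1(C)CC(=O)N(c2ccccc2C(=O)OCC2CCCN(CCCc3ccccc3)C2)C1=O` gives 7500 nM. Across these three the ring-bound substituent on the shared core grows in size, and the numbers fall step by step: a 3.0-fold lower number from compound 1 to compound 2 (0.48 log units; beyond the scatter), a 2.1-fold lower number from compound 2 to compound 3 (0.32 log units; beyond the scatter), and over the whole span a 6.3-fold lower number from compound 1 to compound 3 (0.80 log units; beyond the scatter).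

Compound 4 `O=C(OCC1CCCN(CCCc2ccccc2)C1)c1ccccc1N1C(=O)c2ccccc2C1=O` carries a different kind of change: a group of 11 heavy atoms (8 carbon, 1 nitrogen, 2 oxygen; one five-membered non-aromatic ring with 1 hetero atom, one six-membered aromatic ring of carbon only) in place of a group of 12 heavy atoms (9 carbon, 1 nitrogen, 2 oxygen; one five-membered non-aromatic ring of carbon only, one five-membered non-aromatic ring with 1 hetero atom), on an aromatic carbon, with its place on an aromatic carbon of a six-membered aromatic ring of carbon only, ortho to a large group. Going by the values given here, none of the measured steps involves a fused aromatic ring at this position, so they bear on it only indirectly. The three measured steps show that the number moves modestly with the group at this site, and they reward the larger, carbon-only ring. Compound 4 loses that ring in favour of a six-membered aromatic ring fused to the five-membered ring, and a modest rise in the number is therefore expected, with a 1.8-fold higher number from compound 3 to compound 4 (0.26 log units; within the scatter) near the edge of the scatter. Compound 4 is estimated at 2200 nM in this assay, in a range from 800 nM to 6000 nM.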

Compound 4, half-maximal inhibitory concentration: 1300 nM
The estimate for compound 4 lay 1.7-fold (0.23 log units) above the measured number; the range from low to high includes it.
By their numbers in this assay, from the lowest: compounds 3, 4 and 2 (each within the scatter of the next, the first and the last beyond it); then compound 1.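

In this assay, the group of 11 heavy atoms with its six-membered aromatic ring of carbon only replaces the group carrying the five-membered ring of carbon only with no readable change, a 1.1-fold higher number from compound 3 to compound 4 (0.03 log units; within the scatter), so a five-membered ring of carbon only is not required at this position for a number at this level. The other two steps place the new group relative to the smaller groups: a 1.9-fold lower number from compound 2 to compound 4 (0.28 log units; within the scatter) leaves it inseparable from the group in compound 2, whereas a 5.8-fold lower number from compound 1 to compound 4 (0.76 log units; beyond the scatter) shows a clear gain over the group in compound 1. Compound 4 also fits the earlier link between group size and number, since its group is intermediate in heavy-atom count between those of compound 2 and compound 3, and its number lies within the scatter of both.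

As far as these compounds go, it remains open whether a methoxy group, an amine or a carboxylic acid on the new aromatic ring would move the number in this assay, or whether a longer chain on the shared core would do so. The data shown offer no explanation for why these two quite different groups give such similar numbers.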